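Two Chlorobenzyl Isomers and an Expected Third

The compounds below may be only part of what the source reports. "The series", "measured", "known", "first", "only" and "open" are said of these compounds alone.

Compound 1 `COc1ccc(C2N=C(SCc3ccc(Cl)cc3)NC(C)=C2C(=O)Nc2ccc(F)cc2)cc1OC` — 10.3%
Compound 2 `CC1=C(C(=O)Nc2ccc(F)cc2)C(c2ccc([N+](=O)[O-])cc2)N=C(SCc2ccccc2Cl)N1` — 6.2%

Both compounds were tested in a functional assay on the whole organism (artery, strain albino) with Rattus norvegicus as the target, with a stated time of 60 min, at a dose of 10 mg/kg by the oral route; on this read-out higher numbers stand for more inhibition at the one dose given (going by the name of the read-out) and lower numbers for less inhibition. Of the two numbers, compound 2 sits lowest, yet compound 1 lies within the scatter of it, so the two cannot be told apart. Compound 3 `CC1=C(C(=O)Nc2ccc(F)cc2)C(c2ccc([N+](=O)[O-])cc2)N=C(SCc2ccc(Cl)cc2)N1` is not yet measured and differs from compound 2 in one place: 4-chlorophenyl in place of 2-chlorophenyl on a saturated chain carbon bound to a sulfur. Among the compounds with values here, no measured pair isolates this change, and with both known readings low and close, no step beyond the scatter is expected in this assay in either direction. For compound 3 the expected value is 8%, between 0% and 20%. The expected step is therefore a number 1.8 percentage points higher from compound 2 to compound 3 (within the scatter).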

Compound 3, a percentage reported as inhibition, in the whole organism at one dose (the size of the read-out at that dose, not a potency): 11.8%
For compound 3 the middle estimate is 3.8 percentage points below the measured one; measured number inside the range.
By their numbers in this assay, from the lowest: compounds 2, 1 and 3 (each within the scatter of the next).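

In this assay, 4-chlorophenyl in place of 2-chlorophenyl on a saturated chain carbon bound to a sulfur gives a number 5.6 percentage points higher from compound 2 to compound 3 (within the scatter), so this first direct test of the change finds no difference that can be told apart. With 4-chlorobenzyl kept, 4-nitrophenyl in place of 3,4-dimethoxyphenyl on a saturated ring carbon gives a number 1.5 percentage points higher from compound 1 to compound 3 (within the scatter), so this change also shows no separable effect. No measured evidence bears on these results.

From the compounds shown here alone, both changes swap one aromatic group for another, so the effect of a very different group stays open. An amine or a carboxylic acid in place of 4-chlorophenyl on that chain carbon could still give a different number.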